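The source may hold more compounds than are shown below. What is called first, only, known or untested is meant among the compounds shown, and "the series" means these compounds.

Measured in a functional assay on MCF7 cells (Homo sapiens) for inhibition, read by MTT assay, with a stated time of 72 h, tested at 50 uM; a lower number here means less inhibition of growth, a higher number more inhibition of growth at the concentration tested:
Compound 1 `C=CCc1ccc(OCc2cn(-c3ccccc3Cl)nn2)c(O)c1`: 34.3%
Compound 2 `C=CCc1ccc(OCc2cn(-c3ccc(OC)cc3)nn2)c(O)c1`: 57.2%

Compound 2 stands higher of the two in this assay, and its nearest neighbour, compound 1, lies lower by more than the scatter. The next compound is compound 3 `C=CCc1ccc(OCc2cn(-c3ccccc3CO)nn2)c(O)c1`, and the change is 2-(hydroxymethyl)phenyl in place of 4-methoxyphenyl on an aromatic nitrogen. Within the data shown here, only one measured step bears on it: a number 22.9 percentage points higher from compound 1 to compound 2 (beyond the scatter), a modest step beyond the scatter, which swapped 2-chlorophenyl for 4-methoxyphenyl at the same place. Compound 3 gives up that 4-methoxyphenyl for a group whose name also carries its substituent at 2, so part of that gain in compound 2 may be expected to be lost. Among the measured compounds shown here, no measured compound carries 2-(hydroxymethyl)phenyl, so this expectation is loose. The expected move is a fall of moderate size, a number 13.2 percentage points lower from compound 2 to compound 3 (beyond the scatter). For compound 3 the estimated value is 44%, with an expected range of 26% to 62%.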

Compound 3, percent growth inhibition at one concentration: 40.4%
Compound 3: middle estimate off by 3.6 percentage points, on the high side; low and high end bracket the measured number.
By their numbers in this assay, from the lowest: compounds 1 and 3 (each within the scatter of the next); then compound 2.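

In this assay, 2-(hydroxymethyl)phenyl in place of 4-methoxyphenyl gives a number 16.8 percentage points lower from compound 2 to compound 3 (beyond the scatter), so two groups with the same count of heavy atoms, joined differently, are not interchangeable on this aromatic nitrogen. Hydroxymethyl in place of chloro on an aromatic carbon gives a number 6.1 percentage points higher from compound 1 to compound 3 (within the scatter), so this exchange separates compound 1 and compound 3 by no more than the scatter, and both stand lower than compound 2. No supporting data bear on why these groups differ in this way.

The compounds shown leave open whether the lower numbers follow the identity of the substituent or where it sits on the phenyl ring. They also leave open how an amine or a carboxylic acid in place of hydroxymethyl would read in this assay.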